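Swapping the aryl group on the triazole: compound 3 to 4

This account rests on a few compounds, and the source may have more. Where it says the series, first, only, none or still open, it means among the compounds named here.

Compound 1 `Cc1cc(C)cc(-n2nncc2CN2C(=O)C3(C(C#N)=C(N)Oc4c3c3nc5ccccc5nc3c3ccccc43)c3ccccc32)c1`: in a functional assay on HCT-116 cells (Homo sapiens) for antiproliferative activity, read by MTT assay, with a stated time of 48 h (on this read-out lower numbers stand for stronger inhibition and higher numbers for weaker inhibition), compound 1 gives > 50000 nM, which is a limit of the assay and not a number.
Compound 2 `Cc1ccc(Cl)cc1-n1nncc1CN1C(=O)C2(C(C#N)=C(N)Oc3c2c2nc4ccccc4nc2c2ccccc32)c2ccccc21`: in this assay compound 2 gives > 50000 nM, again a limit.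
Compound 3 `Cc1cccc(-n2nncc2CN2C(=O)C3(C(C#N)=C(N)Oc4c(N)cc5nc6ccccc6nc5c43)c3ccccc32)c1`: in this assay compound 3 gives > 50000 nM, also a limit.

Compound 3 therefore stands at the limit of this assay, with no number of its own; the two other values shown are limits as well, so nothing places compound 3 above or below them.

Compound 4 `N#CC1=C(N)Oc2c(N)cc3nc4ccccc4nc3c2C12C(=O)N(Cc1cnnn1-c1ccccc1Cl)c1ccccc12` differs from compound 3 in one place: 2-chlorophenyl in place of 3-methylphenyl on an aromatic nitrogen.

Among the compounds with values here, only one measured step changes the same aryl group on the aromatic nitrogen, a step that the two limits leave unreadable from compound 1 to compound 2, and its size cannot be read because both ends are limits. The one thing the shown values have in common is the limit of > 50000 nM in this assay, at which 3 of the 3 values shown sit. Within the data shown here, no measured step shows that any aryl group at this position moves the read-out off the limit, so no step beyond the scatter is expected from compound 3 to compound 4.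

Compound 4 is therefore expected to give about 50000 nM in this assay, within 15000 nM to 100000 nM, a change of a number no higher from compound 3 to compound 4 (the limit leaves the size open) from compound 3, and most likely the assay will again report only a limit.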

Compound 4, half-maximal inhibitory concentration: > 50000 nM
Compound 4 was reported as a limit (the forecaster's own chance of this, stated with the estimate: 80%); the middle value sits exactly at the limit.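

Compound 3 and compound 4 are both reported in this assay only as limits, so no step between them can be read, and the same holds for every other pair: the limit of > 50000 nM in this assay, at which 4 of the 4 values shown sit.

The compounds shown leave open whether changing the aryl group on the triazole affects the read-out at all.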